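The compounds below may be only part of what the source reports. "The series", "measured", "known", "first", "only" and "open" are said of these compounds alone.

Working notes on the series. In a functional assay on HOS cells (Homo sapiens) for inhibition, read by CCK-8 assay, with a stated time of 72 h, tested at 1 uM (on this read-out higher numbers stand for more inhibition at the one concentration tested (going by the name of the read-out) and lower numbers for less inhibition), compound 3 `COc1cc(F)ccc1N1C(=O)CSC1c1cccc(C(=O)NCCCCc2ccccc2)c1` gives 81% and stands highest of the three measured; compound 2 `COc1ccc(F)cc1N1C(=O)CSC1c1cccc(C(=O)NCCCCc2ccccc2)c1` gives 46% and compound 1 `COc1ccc(OC)c(N2C(=O)CSC2c2cccc(C(=O)NCCCCc3ccccc3)c2)c1` gives 5%. All three measured steps change only the aryl group on the amide-type nitrogen in the ring: a number 41 percentage points higher from compound 1 to compound 2 (beyond the scatter), a number 76 percentage points higher from compound 1 to compound 3 (beyond the scatter) and a number 35 percentage points higher from compound 2 to compound 3 (beyond the scatter), each large and beyond the scatter. Compound 4 `CC(F)(F)c1cccc(N2C(=O)CSC2c2cccc(C(=O)NCCCCc3ccccc3)c2)c1` differs from compound 3 by a group of 10 heavy atoms (8 carbon, 2 fluorine; one six-membered aromatic ring of carbon only) in place of a group of 9 heavy atoms (7 carbon, 1 oxygen, 1 fluorine; one six-membered aromatic ring of carbon only), on an amide-type nitrogen in a ring. The measured steps show that this aryl group moves this assay strongly, but none of them removes the methoxy entirely, so the direction is open; a drop from compound 3 is expected, of a number 36 percentage points lower from compound 3 to compound 4 (beyond the scatter). Compound 4 is therefore estimated at 45%, in the range 15% to 80%.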

Compound 4, a percentage reported as inhibition, at one concentration (the size of the read-out at that concentration, not a potency): 23%
The estimate for compound 4 lay 22 percentage points above the measured number; the range from low to high includes it.
By their numbers in this assay, from the lowest: compound 1; then compound 4; then compound 2; then compound 3.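

Within the data shown here, compound 4 carries the only aryl group in the set without a methoxy on the amide-type nitrogen in a ring, and it still falls among the methoxy-bearing compounds. The change reads as a number 58 percentage points lower from compound 3 to compound 4 (beyond the scatter) and as a number 23 percentage points lower from compound 2 to compound 4 (beyond the scatter) but also as a number 18 percentage points higher from compound 1 to compound 4 (beyond the scatter) so the methoxy alone does not set the level of inhibition across these compounds. No measurement available here explains these differences.

Open, from the compounds shown here alone, is how a plain phenyl, or a nitrile or morpholine on this aryl group, would compare with compound 3 and compound 4.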